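The source may hold more compounds than are shown below. What is called first, only, known or untested is meant among the compounds shown, and "the series" means these compounds.

Compound 1 `CC1(C)CC(NC(=S)Nc2ccc([N+](=O)[O-])cc2)c2cc(Br)ccc2O1` and compound 2 `CC1(C)CC(NC(=S)Nc2ccc([N+](=O)[O-])cc2)c2cc(Cl)ccc2O1` share one core and differ in a single place: bromo in place of chloro on an aromatic carbon. In a functional assay on B16-F10 cells (Mus musculus) for inhibition, read by MTT assay, with a stated time of 72 h (a higher number here means a weaker inhibitor, a lower number a stronger inhibitor), compound 1 gives 3000 nM, and compound 2 gives 3000 nM, so that no change at the digits printed from compound 2 to compound 1 (within the scatter). Compound 3 `CC1(C)CC(NC(=O)Nc2ccc(Cl)cc2)c2cc(Cl)ccc2O1` is built on a different core; how its core differs from that of compound 2 is not broken down here. In this assay compound 3 gives 32000 nM, the highest number of the three. Compound 4 `CC1(C)CC(NC(=O)Nc2ccc(Cl)cc2)c2cc(Br)ccc2O1` has not yet been measured and differs from compound 3 in one place: bromo in place of chloro on an aromatic carbon, the same change that separates compound 2 from compound 1. Because no change at the digits printed from compound 2 to compound 1 (within the scatter), the expected step is no change at the digits printed from compound 3 to compound 4 (within the scatter). Compound 4 is therefore estimated at 32000 nM, with a likely range from 14000 nM to 70000 nM.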

Compound 4, half-maximal inhibitory concentration: 9000 nM
Compound 4: the middle estimate sits 3.6-fold (0.55 log units) above what was measured; the measured number lies below the stated range.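

In this assay, bromo in place of chloro on the aromatic carbon gives a 3.6-fold lower number from compound 3 to compound 4 (0.55 log units; beyond the scatter). Set beside the earlier step, the same swap does not behave alike on the two cores: the same change on two cores in this assay, no change at the digits printed (within the scatter) from compound 2 to compound 1 and a 3.6-fold lower number (0.55 log units; beyond the scatter) from compound 3 to compound 4, 3.6-fold (0.55 log units) apart, beyond the scatter of two such steps This shows that a step read on one core cannot simply be carried over to the other in this series, but with a single pair on each core it does not show which part of the cores accounts for the gap, or how the swap would behave on a third core.

The compounds shown carry only chloro or bromo at this aromatic carbon. From the compounds shown here alone, how fluoro, a methyl group or an amine there would behave on either core remains open.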